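A few compounds are considered here, and "the series" means these few. Any claim that something is new, unique, unknown or untested is made for them only; others in the source may bear on it.

In a functional assay on KBVIN cells (Homo sapiens) for antiproliferative activity, read by sulforhodamine B assay, with a stated time of 3 days (a lower number here means that less compound is needed, a higher number that more compound is needed for the effect), three compounds that share one core and differ only in the aryl group have been measured so far. Compound 1 `CCC1=C(O)c2c(oc(-c3cccc(OC)c3)cc2=O)C(CC)(CC)C1=O` gives 1.22 uM and compound 2 `CCC1=C(O)c2c(oc(-c3cc(C)c(C)cc3C)cc2=O)C(CC)(CC)C1=O` gives 4.37 uM while compound 3 `CCC1=C(O)c2c(oc(-c3ccc(OC)c(C)c3)cc2=O)C(CC)(CC)C1=O` gives 0.1 uM (the lowest number of the three, clearly apart from both others). Compound 4 `CCC1=C(O)c2c(oc(-c3ccc(OC)c(F)c3)cc2=O)C(CC)(CC)C1=O` differs from compound 3 by a single swap, fluoro in place of methyl on an aromatic carbon, which turns 4-methoxy-3-methylphenyl into 3-fluoro-4-methoxyphenyl. For the measured compounds named here, no measured step makes this swap on its own, so the evidence is indirect. The closest guides are the large 12-fold lower number from compound 1 to compound 3 (1.09 log units; beyond the scatter) and the large 44-fold lower number from compound 2 to compound 3 (1.64 log units; beyond the scatter) together with the modest 3.6-fold higher number from compound 1 to compound 2 (0.55 log units; beyond the scatter) as a third comparison. These steps show that the number moves considerably when this aryl group changes, although each of them alters more than one substituent. Going by the values given here, with compound 3 at 0.1 uM as the lowest number so far and the methoxy group kept, a rise seems more likely than a further fall. The expected change is a 3.0-fold higher number from compound 3 to compound 4 (0.48 log units; beyond the scatter) and would be a modest rise. For compound 4 the estimated value is 0.3 uM with an expected range from 0.08 uM to 1.2 uM in repeat measurements.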

Compound 4, concentration for half-maximal effect: 0.1 uM
For compound 4 the middle estimate is 3.0-fold (0.48 log units) above the measured one; the range from low to high includes it.
By their numbers in this assay, from the lowest: compounds 3 and 4 (each within the scatter of the next); then compound 1; then compound 2.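

In this assay, fluoro in place of methyl on this aromatic carbon, ortho to a methoxy group, gives no change at the digits printed from compound 3 to compound 4 (within the scatter), so the low number of compound 3 does not depend on the methyl group and survives this swap of one atom for another. The 3-fluoro-4-methoxyphenyl group also keeps the wide gap to the other aryl groups, with a 12-fold lower number from compound 1 to compound 4 (1.09 log units; beyond the scatter) and a 44-fold lower number from compound 2 to compound 4 (1.64 log units; beyond the scatter), although each of these two steps alters more than one substituent. No measured evidence here explains why methyl and fluoro give matching numbers at this position.

The compounds shown leave open how much else this position accepts, for example whether chloro, trifluoromethyl or an amine in the same place would also keep the number as low as in compound 3 and compound 4. They also leave open how much the methoxy group itself contributes, a question that an ethoxy group in its place, or a hydroxyl group, would begin to answer.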